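Swapping the sulfonyl ring on a piperidine-bearing indole

A few compounds are considered here, and "the series" means these few. Any claim that something is new, unique, unknown or untested is made for them only; others in the source may bear on it.

Measured so far:
compound 1, `COc1ccc2c(c1)c(C1=CCNCC1)cn2S(=O)(=O)c1ccc2cccnc2c1`, 2 nM
compound 2, `COc1ccc2c(c1)c(C1=CCNCC1)cn2S(=O)(=O)c1cncc2ccccc12`, 3 nM
compound 3, `COc1ccc2c(c1)c(C1CCNCC1)cn2S(=O)(=O)c1ccc2cccnc2c1`, 30 nM

All three were tested in an assay on HEK293 cells for displacement of a labelled ligand from 5-hydroxytryptamine receptor 6 (Homo sapiens), read by scintillation counting; on this read-out lower numbers stand for stronger inhibition and higher numbers for weaker inhibition. Compound 1 and compound 2 share the same core and differ only in the ring attached to the sulfonyl sulfur: isoquinolin-4-yl in place of quinolin-7-yl on a sulfonyl sulfur. This exchange moved the number only slightly, a 1.5-fold higher number from compound 1 to compound 2 (0.18 log units; within the scatter), so the two cannot be told apart.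

Compound 3 keeps the ring of compound 1 on the sulfonyl sulfur but carries a different six-membered ring on the core: a group of 6 heavy atoms (5 carbon, 1 nitrogen; one six-membered non-aromatic ring with 1 hetero atom) in place of a group of 6 heavy atoms (5 carbon, 1 nitrogen; one six-membered non-aromatic ring with 1 hetero atom), on an aromatic carbon. Here the step is large and clearly real, a 15-fold higher number from compound 1 to compound 3 (1.18 log units; beyond the scatter), and compound 3 has the highest number of the three.

Compound 4, `COc1ccc2c(c1)c(C1CCNCC1)cn2S(=O)(=O)c1cncc2ccccc12`, is not yet measured. It stands to compound 3 as compound 2 stands to compound 1: isoquinolin-4-yl in place of quinolin-7-yl on a sulfonyl sulfur. The surroundings of the change are the same in both pairs, so this is the same change seen a second time, now on the core of compound 3.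

Because the earlier step was small, a 1.5-fold higher number from compound 1 to compound 2 (0.18 log units; within the scatter), a similarly small step is expected in this assay, estimated as a 1.3-fold higher number from compound 3 to compound 4 (0.12 log units; within the scatter). Compound 4 is therefore expected to give about 40 nM in this assay, most likely between 15 nM and 120 nM. This expectation rests on one measured pair only, so it is tentative.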

Compound 4, inhibition constant: 24 nM
Estimate against measurement, compound 4: 1.7-fold (0.22 log units) above, within the range that was stated.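

In this assay, putting isoquinolin-4-yl in place of quinolin-7-yl on the sulfonyl sulfur again gives a step within the scatter, a 1.3-fold lower number from compound 3 to compound 4 (0.10 log units; within the scatter), and the two cores treat this exchange alike: the same change on two cores in this assay, a 1.5-fold higher number (0.18 log units; within the scatter) from compound 1 to compound 2 and a 1.3-fold lower number (0.10 log units; within the scatter) from compound 3 to compound 4, 1.9-fold (0.27 log units) apart, within the scatter of two such steps. The other change, the swap of the six-membered non-aromatic ring on the core, also carries over when the sulfonyl ring is isoquinolin-4-yl, an 8.0-fold higher number from compound 2 to compound 4 (0.90 log units; beyond the scatter), and its size holds up across the two sulfonyl rings: the same change on two cores in this assay, a 15-fold higher number (1.18 log units; beyond the scatter) from compound 1 to compound 3 and an 8.0-fold higher number (0.90 log units; beyond the scatter) from compound 2 to compound 4, 1.9-fold (0.27 log units) apart, within the scatter of two such steps. So in these four compounds each change keeps its size whichever form the other part takes, but this is a single set of four compounds in a single assay, and it does not show that the same would hold on any other core or for any other group on the sulfonyl sulfur.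

As far as these compounds go, it remains open whether a sulfonyl ring without a ring nitrogen, such as a plain phenyl or naphthalen-2-yl group, would behave like these two. From the compounds shown here alone, it also remains open whether the large step between the two non-aromatic rings would survive with a methyl group on the ring nitrogen, or with a chlorine in place of the methoxy group.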